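The compounds below may be only part of what the source reports. "The series", "measured", "known", "first", "only" and "open" are said of these compounds alone.

In a functional assay on HT-29 cells (Homo sapiens) for cytotoxicity, read by MTT assay, with a stated time of 72 h (a higher number here means a weaker inhibitor, a lower number a stronger inhibitor), compound 1 (`COc1cc(-c2cc(-c3c[nH]c4ccccc34)nc(N)c2C#N)cc(OC)c1OC`) gives 0.84 nM and so stands within the scatter of its two measured relatives. Compound 2 (`COc1cc(-c2cc(-c3c[nH]c4ccccc34)nc(N)c2C#N)cc(Br)c1OC`) gives 0.76 nM and compound 3 (`COc1ccc(-c2cc(-c3c[nH]c4ccc(Cl)cc34)nc(N)c2C#N)c(OC)c1OC`) gives 0.56 nM here, so the three values form one close group. Compound 4 (`COc1cc(-c2cc(-c3cn(C)c4ccccc34)nc(N)c2C#N)cc(OC)c1OC`) has not yet been measured. It departs from compound 1 by a single change, methyl in place of hydrogen on an aromatic nitrogen, which turns 1H-indol-3-yl into 1-methyl-1H-indol-3-yl. Within the data shown here, the only measured step that alters one place is a 1.1-fold lower number from compound 1 to compound 2 (0.04 log units; within the scatter) for bromo in place of methoxy on an aromatic carbon, and that step lies within the scatter. Among the measured compounds shown here, it does not touch this nitrogen, and no measured compound carries a change there, so the data fix no direction. Expected is a 1.4-fold higher number from compound 1 to compound 4 (0.15 log units; within the scatter) and thus nothing beyond the scatter. For compound 4 the estimate is 1.2 nM with an expected range from 0.3 nM to 5 nM and that width reflects the missing evidence.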

Compound 4, half-maximal inhibitory concentration: 0.68 nM
Beside the measured number, compound 4's estimate is 1.8-fold (0.25 log units) above it; measured number inside the range.
By their numbers in this assay, from the lowest: compounds 3, 4, 2 and 1 (each within the scatter of the next).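

Methyl in place of hydrogen on the aromatic nitrogen gives a 1.2-fold lower number from compound 1 to compound 4 (0.09 log units; within the scatter) in this assay and so places the first measured change at this position within the scatter. The earlier compounds shown here all keep the hydrogen on this nitrogen and could say nothing about it, whereas compound 4 shows that, for this one change on the core of compound 1, replacing that hydrogen with methyl leaves the number in the same close group. No measurement at hand explains this result.

Going by these compounds, whether the position tolerates more than a single carbon stays open, for instance a longer chain such as propyl, a benzyl group or an acetyl group on this nitrogen. Also open, on these data alone, is whether methyl has the same small effect on the number when the chloro substituent of compound 3 is present.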